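Fluoro in Place of Methyl: From Compound 3 to Compound 4

The source may report more compounds than this note shows. Statements on the series, on what has been measured and on what is new or still open speak of the compounds shown alone.

In a functional assay on MGC-803 cells (Homo sapiens) for antiproliferative activity, read by MTT assay (a lower number here means a stronger inhibitor, a higher number a weaker inhibitor), compound 2 `O=C(Nc1cccc(Cl)c1)Nc1cccc(CNc2ncnc3ccccc23)c1` gives 19200 nM. Compound 1 `O=C(Nc1cccc(CNc2ncnc3ccccc23)c1)Nc1ccccc1Cl` returns only the limit > 50000 nM in this assay. The step of an at least 2.6-fold lower number from compound 1 to compound 2 (0.41 log units; beyond the scatter) separates these two compounds, with the limit of > 50000 nM in this assay, at which 1 of the 3 values shown sits, marking where the step begins. Compound 3 `COc1cc2ncnc(NCc3cccc(NC(=O)Nc4ccc(C)cc4)c3)c2cc1OC`, which carries two methoxy groups on the shared core, gives 34200 nM in this assay, the higher of the two numbers recorded; its nearest neighbour is compound 2, and the gap between them lies within the scatter, so no order between compound 2 and compound 3 can be read from the data.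

Compound 4 `COc1cc2ncnc(NCc3cccc(NC(=O)Nc4ccc(F)cc4)c3)c2cc1OC` differs from compound 3 in a single place: fluoro in place of methyl on an aromatic carbon. Among the compounds with values here, no measured step bears on this exchange. Within the data shown here, the only step measured, an at least 2.6-fold lower number from compound 1 to compound 2 (0.41 log units; beyond the scatter), swaps 2-chlorophenyl for 3-chlorophenyl on an amide-type nitrogen and says nothing about replacing methyl with fluoro on the phenyl that carries it. Among the measured compounds shown here, with no comparable step to draw on, the expected change a 1.0-fold lower number from compound 3 to compound 4 (0.00 log units; within the scatter) is none beyond the scatter. Compound 4 is therefore estimated at 34000 nM in this assay, with a range from 12000 nM to 100000 nM.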

Compound 4, half-maximal inhibitory concentration: 42100 nM
Compound 4: middle estimate off by 1.2-fold (0.09 log units), on the low side; measured number inside the range.
By their numbers in this assay, from the lowest: compounds 2, 3 and 4 (each within the scatter of the next, the first and the last beyond it). At a limit, above all of these: compound 1.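

In this assay, within the data shown here, the step of a 1.2-fold higher number from compound 3 to compound 4 (0.09 log units; within the scatter) is the first reading at this place, on an aromatic carbon of the six-membered ring and para to a large group, and it shows that 4-fluorophenyl and 4-methylphenyl cannot be told apart here, so the two compounds take no order. Among these compounds, the earlier compounds could not show this: their only step exchanged 2-chlorophenyl for 3-chlorophenyl, which concerns where a chloro group sits on the ring, whereas this step keeps the place fixed and exchanges the group, on a core that carries two methoxy groups. Nothing shown here gives a reason for the result, and no information on any property of methyl or fluoro bears on it.

The compounds shown leave open whether a group of another kind at this same place, such as an amine, a carboxylic acid or a longer alkyl chain, would move the number beyond the scatter. They also leave open whether fluoro in place of methyl would read the same on the core without the two methoxy groups.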